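The source may hold more compounds than are shown below. What is called first, only, known or untested is meant among the compounds shown, and "the series" means these compounds.

Four compounds share a sugar attached to a fused two-ring core, and differ in the group on one carbon of that core and in the core itself. Compound 1 `COc1nc(N)nc2c1c(-c1ccsc1)cn2[C@@H]1O[C@H](CO)[C@@H](O)[C@H]1O` and compound 2 `C#Cc1cn([C@@H]2O[C@H](CO)[C@@H](O)[C@H]2O)c2nc(N)nc(OC)c12` share one core; compound 3 `C#Cc1cn([C@@H]2O[C@H](CO)[C@@H](O)[C@H]2O)c2ncnc(SC)c12` and compound 4 `CSc1ncnc2c1c(-c1ccsc1)cn2[C@@H]1O[C@H](CO)[C@@H](O)[C@H]1O` share another. The difference between the two cores is not broken down here.

Cell growth was followed in a functional assay on HCT-116 cells (Homo sapiens), read by MTT assay, with a stated time of 72 h; on this read-out higher numbers stand for weaker inhibition and lower numbers for stronger inhibition. For compound 1 only a limit of the assay, > 20000 nM, was reached. For compound 2 the result is likewise a limit, > 20000 nM. Compound 3 gives a number, 90 nM, in this assay. Between compound 2 and compound 1 the change is thiophen-3-yl in place of ethynyl on an aromatic carbon; the step that the two limits leave unreadable from compound 2 to compound 1 cannot be read, since both ends sit at the limit of > 20000 nM in this assay, at which 2 of the 3 values shown sit.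

Compound 4 is not yet measured. It arises from compound 3 by thiophen-3-yl in place of ethynyl on an aromatic carbon, the same change as from compound 2 to compound 1, made at the same place. For the measured compounds named here, because the only earlier example of this change is hidden at the limit of > 20000 nM in this assay, at which 2 of the 3 values shown sit, no measured step shows what it does to potency, and the expectation for compound 4 rests on compound 3 alone at 90 nM together with the possibility that the larger ring shifts the value either way. The expected step is a 3.3-fold higher number from compound 3 to compound 4 (0.52 log units; beyond the scatter), with wide uncertainty. Compound 4 is thus estimated at 300 nM, between 60 nM and 3000 nM.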

Compound 4, half-maximal inhibitory concentration: > 20000 nM
Compound 4: a limit, no number; the forecaster's own chance of this, stated with the estimate: 15%; middle value at least 66-fold (1.82 log units) from the limit.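

In this assay, putting thiophen-3-yl in place of ethynyl on the core with the sulfur-linked methyl group gives an at least 220-fold higher number from compound 3 to compound 4 (2.34 log units; beyond the scatter), so on this core the change removes nearly all of the measurable effect on cell growth. Compound 4 gives > 20000 nM, which is a limit of the assay and not a number, so the step has a lower bound but no exact size. The same change on the other core cannot be read, which means the series offers one bounded example and does not show whether the change acts alike on both cores, because both ends of that other step share the value now reached by compound 4 as well: the limit of > 20000 nM in this assay, at which 3 of the 4 values shown sit.

On these data alone, only ethynyl and thiophen-3-yl appear on this carbon, so it remains open how another group there, such as methyl, a nitrile or an amine, would read in this assay. No pair shown differs in the core alone, so what the core change does by itself, with ethynyl or with thiophen-3-yl held fixed, also stays open.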